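Bromo to phenyl on the thiourea aryl ring

This account rests on a few compounds, and the source may have more. Where it says the series, first, only, none or still open, it means among the compounds named here.

Compound 1 `NC(=O)c1c(NC(=O)c2ccccc2Cl)sc2c1CCN(Cc1ccccc1F)C2` and compound 2 `NC(=O)c1c(NC(=O)c2ccccc2Cl)sc2c1CCN(C(=S)Nc1ccccc1Br)C2` share a core and differ only in the group on the ring amine nitrogen. In a functional assay on MKN-74 cells (Homo sapiens) for antiproliferative activity, with a stated time of 24 h (on this read-out higher numbers stand for weaker inhibition and lower numbers for stronger inhibition), compound 1 gives 12900 nM, and compound 2 gives 10800 nM; the step of a 1.2-fold lower number from compound 1 to compound 2 (0.08 log units; within the scatter) leaves the two numbers indistinguishable within the scatter, so compound 2 stands level with compound 1 rather than apart from it. Compound 3 `NC(=O)c1c(NC(=O)c2ccccc2Cl)sc2c1CCN(C(=S)Nc1ccccc1-c1ccccc1)C2` carries phenyl in place of bromo on an aromatic carbon. Within the data shown here, no measured step touches this position; the single step seen, from the fluorobenzyl group to the bromophenyl thiourea, concerned a different part of the molecule and was itself within the scatter, so it offers no direction for this change. The expected change, a 1.1-fold lower number from compound 2 to compound 3 (0.03 log units; within the scatter), is estimated to stay within the scatter. Compound 3 is therefore expected to give 10000 nM, in a range from 4000 nM to 25000 nM.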

Compound 3, half-maximal inhibitory concentration: 25800 nM
Compound 3: the middle estimate sits 2.6-fold (0.41 log units) below what was measured; measured number outside the range, above it.
By their numbers in this assay, from the lowest: compounds 2, 1 and 3 (each within the scatter of the next, the first and the last beyond it).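

Among these compounds, the change from bromo to phenyl, on an aromatic carbon ortho to a large group, gives the first step in this assay that lies beyond the scatter: a 2.4-fold higher number from compound 2 to compound 3 (0.38 log units; beyond the scatter). This shows that the thiourea aryl ring is sensitive to what this position carries, with phenyl going with weaker inhibition than bromo, although the effect is modest and rests on this single pair. Nothing at hand accounts for the shift.

With only bromo and phenyl shown at this position, it remains open how a hydrogen, a methyl, a methoxy, an amine or a carboxylic acid on the same carbon would read. On these data alone, it is also open whether replacing bromo with phenyl would have the same effect with a different group elsewhere on the molecule.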